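Polybrominated diaryl ether series: cytotoxicity working notes

The source may hold more compounds than are shown below. What is called first, only, known or untested is meant among the compounds shown, and "the series" means these compounds.

Two members of this series have been run in a functional assay on U-937 cells (Homo sapiens) for cytotoxicity, read by MTT assay, with a stated time of 24 h; a higher number here means a weaker inhibitor, a lower number a stronger inhibitor. Compound 1 `COc1c(Br)cc(Br)cc1Oc1ccc(Br)cc1Br` gives 34.5 ug/mL in this assay, the lowest of the two numbers recorded so far. Among the compounds with values here, compound 2 `Brc1ccc(Oc2cc(Br)cc(Br)c2OCCCCCN2CCN(c3ccccc3)CC2)c(Br)c1` gives 42.5 ug/mL in this assay; its number lies within the scatter of that of compound 1, so the two values cannot be told apart, and no single-point step connects the two structures.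

Compound 3 `CC(C)(C)C(=O)C(C#N)Oc1c(Br)cc(Br)cc1Oc1ccc(Br)cc1Br` is not yet measured. It differs from compound 1 in one place: cyano((tert-butyl)carbonyl)methyl in place of methyl on an oxygen on an aromatic ring. Nothing measured in the series speaks to this kind of change, since compound 2 alters the core of compound 1 in several places at once.

Within the data shown here, with no measured step to lean on, the expectation is that the step from compound 1 to compound 3 in this assay stays within the scatter, with no clear direction, as expressed by a 1.2-fold lower number from compound 1 to compound 3 (0.06 log units; within the scatter). For compound 3 the number in this assay is estimated at 30 ug/mL, with a range from 12 ug/mL to 75 ug/mL.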

Compound 3, half-maximal inhibitory concentration: 32.5 ug/mL
The estimate for compound 3 lay 1.1-fold (0.03 log units) below the measured number; the range from low to high includes it.
By their numbers in this assay, from the lowest: compounds 3, 1 and 2 (each within the scatter of the next).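

Within the data shown here, the only single-place step so far is a 1.1-fold lower number from compound 1 to compound 3 (0.03 log units; within the scatter) in this assay, and it belongs to cyano((tert-butyl)carbonyl)methyl in place of methyl on an oxygen on an aromatic ring. At this position, a group of 9 heavy atoms with 2 hydrogen-bond acceptors therefore stands in place of a group of 1 heavy atom with no change that can be told from the scatter, so this substituent swap gives no measurable shift in the read-out. Nothing available on these compounds accounts for this result.

On these data alone, whether any group on this oxygen can move the number beyond the scatter remains open, for instance a free hydroxyl, a carboxylic acid or a short chain ending in an amine. The bromines of the shared core also remain unaddressed by any single-place step, so the present result speaks only to this oxygen and only to this assay as a read-out.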